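The source may hold more compounds than are shown below. What is called first, only, known or untested is meant among the compounds shown, and "the series" means these compounds.

Of the compounds shown here, three with a shared core have been tested in an assay on HL-60 cells for inhibition of glutathione S-transferase P (Homo sapiens), read by spectrophotometry, tested at 20 uM; a higher number here means more inhibition at the concentration tested (going by the name of the read-out), a lower number less inhibition. Compound 1, `COc1ccccc1/C=C1\CN(CC(=O)O)c2c(C)cccc2C1=O`, gives 4.72%. Compound 2, `COc1ccc(OC)c(/C=C2\CN(CC(=O)O)c3c(C)cccc3C2=O)c1`, gives 5.44%, and compound 3, `Cc1cc(C)cc(/C=C2\CN(CC(=O)O)c3c(C)cccc3C2=O)c1`, gives 17.5%. Compound 1 thus has the lowest of the three numbers: the step of a number 0.7 percentage points higher from compound 1 to compound 2 (within the scatter) stays within the scatter, while the step of a number 12.8 percentage points higher from compound 1 to compound 3 (beyond the scatter) lies beyond it.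

Compound 4, `CCOc1ccccc1/C=C1\CN(CC(=O)O)c2c(C)cccc2C1=O`, is not yet measured. It differs from compound 1 as follows: methyl in place of hydrogen on a saturated chain carbon bound to an oxygen on an aromatic ring. Among the compounds with values here, no measured step changes this same place, so only a loose comparison is available. The nearest parallel is the addition of a single methoxy in the step of a number 0.7 percentage points higher from compound 1 to compound 2 (within the scatter), which produced no change beyond the scatter; the larger step to compound 3 exchanges the whole aryl group and so says little about a one-carbon lengthening. The expectation for compound 4 is therefore a step of about a number 1.3 percentage points higher from compound 1 to compound 4 (within the scatter), which is within the scatter. Compound 4 is estimated at 6%, with a range from 0% to 16%.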

Compound 4, a percentage reported as inhibition, at one concentration (the size of the read-out at that concentration, not a potency): 15.4%
Compound 4: middle estimate off by 9.4 percentage points, on the low side; measured number inside the range.
By their numbers in this assay, from the lowest: compounds 1, 2, 4 and 3 (each within the scatter of the next, the first and the last beyond it).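

In this assay, the single methyl that turns the methoxy of the earlier compound into an ethoxy gives a number 10.7 percentage points higher from compound 1 to compound 4 (beyond the scatter). Within the data shown here, none of the earlier steps altered this group alone, so this is the first sign that the read-out responds to a change of one carbon on the saturated chain carbon bound to an oxygen on an aromatic ring. There is no independent measurement that bears on why this small addition changes the number.

A single step cannot show whether the number would keep rising with a longer chain such as propoxy or would fall again. It also leaves open what a branched isopropoxy, or an amine or a hydroxyl in place of the added methyl, would do.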